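Compound 4: a fluorinated swap on the compound 2 scaffold

The source may report more compounds than this note shows. Statements on the series, on what has been measured and on what is new or still open speak of the compounds shown alone.

Values in a functional assay on HepG2 cells (Homo sapiens) for cytotoxicity, read by MTT assay, with a stated time of 24 h; a higher number here means a weaker inhibitor, a lower number a stronger inhibitor:
Compound 1 `N#Cc1ccc(/C=C2\CN(S(=O)(=O)c3ccc(F)cc3)C/C(=C\c3ccc(C#N)cc3)C2=O)cc1`: 11500 nM
Compound 2 `CC(=O)Nc1ccc(S(=O)(=O)N2C/C(=C\c3ccc(C#N)cc3)C(=O)/C(=C/c3ccc(C#N)cc3)C2)cc1`: 4880 nM
Compound 3 `O=C1/C(=C/c2cccc([N+](=O)[O-])c2)CN(S(=O)(=O)c2ccc(F)cc2)C/C1=C\c1ccccc1F`: 7040 nM

Compound 2, at 4880 nM, and compound 3, at 7040 nM, lie within the scatter of each other, so neither can be ranked ahead. Compound 1 stands further off, with a 2.4-fold lower number from compound 1 to compound 2 (0.37 log units; beyond the scatter).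

The unmeasured compound 4 `CC(=O)Nc1ccc(S(=O)(=O)N2C/C(=C\c3ccc(C#N)cc3)C(=O)/C(=C/c3ccccc3F)C2)cc1` keeps the acetamido group of compound 2. The structural change is 2-fluorophenyl in place of 4-cyanophenyl on a double-bonded chain carbon bound to a double-bonded ring carbon.

Among the measured compounds shown here, the only measured step is modest and concerns acetamido in place of fluoro on an aromatic carbon, a different place, so it does not size this swap. For the measured compounds named here, no measured pair isolates the new change. Compound 3 also carries a 2-fluorophenyl group, though it differs from compound 2 elsewhere too, and compound 3, at 7040 nM, stays within the scatter of compound 2. On that limited evidence, no step beyond the scatter is expected in this assay, in either direction.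

The expected change is a 1.1-fold higher number from compound 2 to compound 4 (0.05 log units; within the scatter).

For compound 4 the estimated value is 5500 nM, with an expected range of 2600 nM to 11000 nM.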

Compound 4, half-maximal inhibitory concentration: 4960 nM
Beside the measured number, compound 4's estimate is 1.1-fold (0.04 log units) above it; low and high end bracket the measured number.
By their numbers in this assay, from the lowest: compounds 2, 4, 3 and 1 (each within the scatter of the next, the first and the last beyond it).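

In this assay, among the compounds shown here, the swap of 4-cyanophenyl for 2-fluorophenyl on a double-bonded chain carbon bound to a double-bonded ring carbon gives a 1.0-fold higher number from compound 2 to compound 4 (0.01 log units; within the scatter) and is the only measured step at this position, since the earlier step concerned the acetamido site. With the acetamido group and the remaining 4-cyanophenyl held in common, compound 2 and compound 4 cannot be told apart in this read-out, even though one nitrile leaves the molecule and a fluorine enters. No data shown here explain why the two groups read alike.

The compounds shown leave open whether this position would accept groups of another kind, such as a plain phenyl, a phenyl carrying a dimethylamino group or a phenyl carrying a carboxylic acid. They also leave open whether the same swap at the remaining 4-cyanophenyl, or the same swap with the fluoro group in place of the acetamido group, would stay within the scatter.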